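From a carbamoyl-bearing ring to an isopropyl pyrazole

This account rests on a few compounds, and the source may have more. Where it says the series, first, only, none or still open, it means among the compounds named here.

Compound 1 `CCNC(=O)c1noc(-c2cc(C(C)C)c(O)cc2O)c1-c1cc(CNC)no1`: 164 nM
Compound 2 `CCNC(=O)c1noc(-c2cc(C(C)C)c(O)cc2O)c1-c1cc(CNC(C)C)no1`: 109 nM
Compound 3 `CCNC(=O)c1noc(-c2cc(C(C)C)c(O)cc2O)c1-c1cc(C(N)=O)no1`: 79 nM

These values come from a functional assay on HCT-116 cells (Homo sapiens) for inhibition; on this read-out lower numbers stand for stronger inhibition and higher numbers for weaker inhibition. Compound 3 is separated from compound 1 but not from compound 2. The data show a 2.1-fold lower number from compound 1 to compound 3 (0.32 log units; beyond the scatter), along with a 1.4-fold lower number from compound 2 to compound 3 (0.14 log units; within the scatter) and a 1.5-fold lower number from compound 1 to compound 2 (0.18 log units; within the scatter).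

Compound 4 `CCNC(=O)c1noc(-c2cc(C(C)C)c(O)cc2O)c1-c1ccn(C(C)C)n1` differs from compound 3 by one exchange: 1-isopropyl-1H-pyrazol-3-yl in place of 3-carbamoyl-1,2-oxazol-5-yl on an aromatic carbon. It sits on an aromatic carbon of a five-membered aromatic ring with 1 nitrogen and 1 oxygen.

The measured steps only alter a side group on the ring that leaves, so they are an indirect guide. Among the compounds with values here, no measured compound carries the entering group. The largest measured step, a 2.1-fold lower number from compound 1 to compound 3 (0.32 log units; beyond the scatter), is modest, so no step beyond the scatter is expected in this assay.

The estimated step is a 1.4-fold higher number from compound 3 to compound 4 (0.14 log units; within the scatter).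

The estimated value for compound 4 is 110 nM, with an expected range from 35 nM to 350 nM.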

Compound 4, half-maximal inhibitory concentration: 19 nM
Compound 4: middle estimate off by 5.8-fold (0.76 log units), on the high side; the measured number lies below the stated range.
By their numbers in this assay, from the lowest: compound 4; then compounds 3, 2 and 1 (each within the scatter of the next, the first and the last beyond it).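

Exchanging the ring itself, rather than a side group on it, gives a 4.2-fold lower number from compound 3 to compound 4 (0.62 log units; beyond the scatter) in this assay, and the same exchange gives a 5.7-fold lower number from compound 2 to compound 4 (0.76 log units; beyond the scatter) and an 8.6-fold lower number from compound 1 to compound 4 (0.94 log units; beyond the scatter) for the two rings with amine side chains. Compound 4 therefore has the lowest number of the four, so this position needs neither a carbamoyl group nor an amine side chain for strong inhibition.

From the compounds shown here alone, what a methyl or a tert-butyl group would give in place of the isopropyl on the pyrazole stays open. No measurement at hand explains the gain.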